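A Second Chloro on the Aniline Ring

The source may report more compounds than this note shows. Statements on the series, on what has been measured and on what is new or still open speak of the compounds shown alone.

Three compounds share one core and differ only in the aryl group on the amine. Compound 1 `C=CC(=O)Nc1cccc(NC(=O)CSc2nc(Nc3cccc(F)c3)c3ccccc3n2)c1` gives 8160 nM in a functional assay on MDA-MB-231 cells (Homo sapiens) for inhibition, read by MTT assay, with a stated time of 72 h; a lower number here means a stronger inhibitor, a higher number a weaker inhibitor. Compound 2 `C=CC(=O)Nc1cccc(NC(=O)CSc2nc(Nc3cccc(Cl)c3)c3ccccc3n2)c1` gives 16300 nM, and compound 3 `C=CC(=O)Nc1cccc(NC(=O)CSc2nc(Nc3ccc(Cl)cc3)c3ccccc3n2)c1` gives 10300 nM. Compound 3 thus sits between the other two, though all three numbers lie within the usual scatter of one another, so none can be called the stronger or weaker inhibitor.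

Compound 4 `C=CC(=O)Nc1cccc(NC(=O)CSc2nc(Nc3ccc(Cl)cc3Cl)c3ccccc3n2)c1` is built from compound 3 by one change: chloro in place of hydrogen on an aromatic carbon. Read one bond further out, this turns 4-chlorophenyl into 2,4-dichlorophenyl.

For the measured compounds named here, no measured step adds a second chloro, so the bearing of earlier steps is indirect. Swapping the halogen gave a 2.0-fold higher number from compound 1 to compound 2 (0.30 log units; within the scatter); moving the halogen around the ring gave a 1.3-fold higher number from compound 1 to compound 3 (0.10 log units; within the scatter) and a 1.6-fold lower number from compound 2 to compound 3 (0.20 log units; within the scatter). Each change to this ring left the number essentially where it was. Adding one more chloro is therefore expected to do little, with no direction beyond the scatter.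

The estimated step is a 1.0-fold lower number from compound 3 to compound 4 (0.01 log units; within the scatter). Compound 4 is expected to give about 10000 nM, most likely between 4000 nM and 25000 nM in this assay.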

Compound 4, half-maximal inhibitory concentration: 23100 nM
Compound 4: middle estimate off by 2.3-fold (0.36 log units), on the low side, within the range that was stated.
By their numbers in this assay, from the lowest: compounds 1, 3, 2 and 4 (each within the scatter of the next, the first and the last beyond it).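

In this assay, for the compounds shown here, this is the first change to the aniline ring whose step clears the scatter, and it is an addition rather than a swap: chloro in place of hydrogen, on the aromatic carbon ortho to a large group and meta to a chloro group, gives a 2.2-fold higher number from compound 3 to compound 4 (0.35 log units; beyond the scatter) and so a weaker inhibitor than compound 3. Compound 4 also reads as weaker than the fluoro compound, with a 2.8-fold higher number from compound 1 to compound 4 (0.45 log units; beyond the scatter) as the second step beyond the scatter, so adding this chloro costs something that swapping or moving a single halogen did not clearly show. Against the 3-chlorophenyl compound there is only a 1.4-fold higher number from compound 2 to compound 4 (0.15 log units; within the scatter), which stays within the scatter, so compound 2 and compound 4 cannot be told apart and the loss is modest rather than a new low for the series.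

The compounds shown do not separate the effect of a chloro at this ortho position alone from that of having two chloro groups on the ring, and they do not show how a methyl, a methoxy or an amine would read on the same carbon. Nothing available here explains why the number moves with this change.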